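The source may hold more compounds than are shown below. What is called first, only, known or untested is meant among the compounds shown, and "the series" means these compounds.

Working notes on the allyl phenol series built on the core of compound 1 `C=CCc1cc(-c2ccccc2C(F)(F)F)ccc1O`, which carries a trifluoromethyl group. In a functional assay on HepG2 cells (Homo sapiens) for antiproliferative activity, read by MTT assay, with a stated time of 24 h (on this read-out higher numbers stand for weaker inhibition and lower numbers for stronger inhibition), compound 1 gives 52400 nM. Compound 2 `C=CCc1cc(-c2cccc([N+](=O)[O-])c2)ccc1O` carries a nitro group in place of the trifluoromethyl. In this assay compound 2 returns only the limit > 100000 nM, not a number. Compound 3 `C=CCc1cc(-c2cccc([N+](=O)[O-])c2)ccc1OC` puts methyl in place of hydrogen on an oxygen on an aromatic ring. In this assay compound 3 likewise returns only the limit > 100000 nM, not a number. The step that the two limits leave unreadable from compound 2 to compound 3 is not readable because of the limit of > 100000 nM in this assay, at which 2 of the 3 values shown sit. Among the measured compounds shown here, compound 3 therefore stands at the limit, and compound 1 is the only compound in the set with a numbered value.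

Compound 4 `C=CCOc1ccc(-c2cccc([N+](=O)[O-])c2)cc1CC=C` differs from compound 3 by vinyl in place of hydrogen on a saturated chain carbon bound to an oxygen on an aromatic ring. For the measured compounds named here, no measured step bears directly on this change. Going by the values given here, the only step available, a step that the two limits leave unreadable from compound 2 to compound 3, concerns the same oxygen and is unreadable, both of its ends sitting where the limit of > 100000 nM in this assay, at which 2 of the 3 values shown sit, sits. On that basis no movement beyond the scatter is expected in this assay, and compound 4 is expected to remain at the limit. The estimate for compound 4 is 150000 nM, with a range from 50000 nM to 500000 nM. The expected step that the limit leaves unreadable from compound 3 to compound 4 is accordingly taken as negligible.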

Compound 4, half-maximal inhibitory concentration: > 100000 nM
Compound 4: only a limit was reported (the forecaster's own chance of this, stated with the estimate: 75%); the middle value lies beyond the limit too.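

In this assay compound 4 gives > 100000 nM as a limit, not a number. No step among compound 2, compound 3 and compound 4 can be read: the limit of > 100000 nM in this assay, at which 3 of the 4 values shown sit.

The compounds shown leave open how methyl or allyl in place of hydrogen on the oxygen would read on a compound with a numbered value, such as compound 1.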